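The compounds below may be only part of what the source reports. "The series", "measured", "known", "first", "only" and "open" are said of these compounds alone.

In an in vitro ADME assay for pharmacokinetics, in phosphate buffer (on this read-out higher numbers stand for a longer-lived compound and lower numbers for a shorter-lived compound), compound 1 `NC1=NC(OCc2ccco2)c2[nH]cnc2N1` gives 0.38 h, the lower of the two plain numbers recorded. Its nearest neighbour is compound 2 `NC1=NC(OCc2cccs2)c2[nH]cnc2N1`, which in this assay gives 0.67 h; the step of a 1.8-fold higher number from compound 1 to compound 2 (0.25 log units; within the scatter) lies within the scatter, so the two cannot be set in order. Compound 3 `NC1=NC(OCc2ccc[n+]([O-])c2)c2[nH]cnc2N1` is reported only as a limit of this assay, > 48 h, not as a number. This is the limit of > 48 h in this assay, at which 1 of the 3 values shown sits, and it is the only such case among the three values. The unmeasured compound 4 `NC1=NC(OCc2cnsc2)c2[nH]cnc2N1` differs from compound 1 as follows: 1,2-thiazol-4-yl in place of furan-2-yl on a saturated chain carbon bound to an oxygen on a saturated carbon. For the measured compounds named here, only the step from compound 1 to compound 2 bears directly on this change, since it too swaps the furan-2-yl for another five-membered aromatic ring at the same place, and that step stayed within the scatter. Going by the values given here, compound 3 shows that a different ring at this place can reach the limit of this assay, but no step to it is recorded. The expected step for compound 4 is therefore a 2.4-fold higher number from compound 1 to compound 4 (0.37 log units; beyond the scatter), a modest rise at most and hardly separable from the scatter. The estimated half-life for compound 4 is 0.9 h, with a range from 0.3 h to 3.5 h.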

Compound 4, half-life: > 48 h
Compound 4: only a limit was reported; the forecaster's own chance of this, stated with the estimate: 10%; at least 53-fold (1.72 log units) between middle value and limit.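

In this assay, the place on a saturated chain carbon bound to an oxygen on a saturated carbon proves far more sensitive than a 1.8-fold higher number from compound 1 to compound 2 (0.25 log units; within the scatter) had suggested: 1,2-thiazol-4-yl in place of furan-2-yl gives an at least 120-fold higher number from compound 1 to compound 4 (2.10 log units; beyond the scatter), and the same group in place of thiophen-2-yl gives an at least 71-fold higher number from compound 2 to compound 4 (1.85 log units; beyond the scatter). Compound 4 gives > 48 h, which is a limit of the assay and not a number. A five-membered aromatic ring at this place can therefore reach the same limit as the ring of compound 3, so the low numbers of compound 1 and compound 2 do not hold for every five-membered aromatic ring: the limit of > 48 h in this assay, at which 2 of the 4 values shown sit.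

Going by these compounds, compound 3 and compound 4 both stand at the limit, so they cannot be set in order, and how far either lies beyond it remains open. The compounds shown also leave open whether the rise follows the second hetero atom or this particular ring, and whether a 1,3-thiazol-2-yl or a phenyl ring at this place would stay with compound 1 and compound 2 or reach the limit.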